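Swapping the Amine Link for Sulfur on a Shared Core

This account rests on a few compounds, and the source may have more. Where it says the series, first, only, none or still open, it means among the compounds named here.

Three compounds share one core and differ only in the arm attached to it. Compound 1 `Nc1cc(N)c2nc(-c3ccccc3)c(NCc3ccc(Cl)c(Cl)c3)nc2c1` gives 18600 nM in a functional assay on SK-OV-3 cells (Homo sapiens) for inhibition, read by sulforhodamine B assay, with a stated time of 48 h; on this read-out higher numbers stand for weaker inhibition of growth and lower numbers for stronger inhibition of growth. Compound 2 `COc1ccc(CNc2nc3cc(N)cc(N)c3nc2-c2ccccc2)cc1OC` gives 21900 nM in this assay, and compound 3 `Nc1cc(N)c2nc(-c3ccccc3)c(NCc3ccc(F)cc3)nc2c1` gives 12900 nM in this assay. Compound 3 has the lowest of the three numbers, but the gaps to the others are small: a 1.4-fold lower number from compound 1 to compound 3 (0.16 log units; within the scatter) and a 1.7-fold lower number from compound 2 to compound 3 (0.23 log units; within the scatter); likewise a 1.2-fold higher number from compound 1 to compound 2 (0.07 log units; within the scatter). Within the scatter, then, the three stand together.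

Compound 4 `Nc1cc(N)c2nc(-c3ccccc3)c(Sc3ccc(F)cc3)nc2c1` alters a different part of the arm: (4-fluorophenyl)sulfanyl in place of (4-fluorobenzyl)amino on an aromatic carbon. For the measured compounds named here, none of the measured steps touches this link; all three exchange one aromatic ring for another on the same saturated chain carbon, and all three stay within the scatter. They show that the ring at the end of the arm has made little difference so far, but say nothing about exchanging the linking group itself. From the compounds shown here alone, the expectation for compound 4 therefore rests on the measured numbers staying close together, with a wide allowance for what is untested. For compound 4 the expected step is a 1.2-fold higher number from compound 3 to compound 4 (0.07 log units; within the scatter). Compound 4 is estimated at 15000 nM in this assay, within a range from 5000 nM to 50000 nM.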

Compound 4, concentration for 50% growth inhibition: 15800 nM
For compound 4 the middle estimate is 1.1-fold (0.02 log units) below the measured one, and the stated range covers the measured number.
By their numbers in this assay, from the lowest: compounds 3, 4, 1 and 2 (each within the scatter of the next).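

Earlier steps exchanged only the ring at the end of the arm, whereas this one replaces the link itself: (4-fluorophenyl)sulfanyl in place of (4-fluorobenzyl)amino on an aromatic carbon gives a 1.2-fold higher number from compound 3 to compound 4 (0.09 log units; within the scatter) in this assay. The swap puts sulfur where the nitrogen stood, removes the saturated chain carbon and takes the hydrogen-bond donor count of the arm from 1 to 0, yet the two numbers remain within the scatter of each other, so this position tolerates a change of link as well as a change of ring in this read-out. Nothing measured here explains why the numbers stay together, and a single step that alters the link atom and the chain at once cannot separate those two changes.

The compounds shown leave open whether a (4-fluorobenzyl)sulfanyl arm, which would pair sulfur with the chain carbon, would read like compound 3 and compound 4. From the compounds shown here alone, an oxygen link or a sulfonyl link at the same aromatic carbon, or a longer chain in the arm, also remains open, and any of these might move the number beyond the scatter.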